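A few compounds are considered here, and "the series" means these few. Any claim that something is new, unique, unknown or untested is made for them only; others in the source may bear on it.

Compounds measured so far, in a functional assay on HCT-116 cells (Homo sapiens) for cytotoxicity, read by MTT assay, with a stated time of 72 h; on this read-out lower numbers stand for stronger inhibition and higher numbers for weaker inhibition:

compound 1 `COc1cc2nc(Cc3ccc(Cl)cc3)[nH]c(=O)c2cc1OC` – 9000 nM
compound 2 `COc1cc2nc(Cc3cccc4ccccc34)[nH]c(=O)c2cc1OC` – 1700 nM
compound 3 `COc1ccc(-c2nc(N=[N+]=[N-])c3cc(OC)c(OC)cc3n2)cc1` – 10000 nM

Compound 3 carries the highest of the three numbers in this assay, but it is not set apart from compound 1: the two numbers lie within the usual scatter of each other, so no order can be read between them. Only compound 2 stands clearly apart, its number being lower than that of compound 3 by more than the scatter allows. Compound 3 is also the only one of the three whose structure is shared with the next compound to be measured.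

Compound 4 `COc1cc2nc(-c3ccc(C)cc3)nc(N=[N+]=[N-])c2cc1OC` differs from compound 3 in a single place: methyl in place of methoxy on an aromatic carbon. Going by the values given here, no pair of measured compounds shows this same change, so there is no measured step to lean on; the expectation rests on the small size of the change alone. Compound 4 is therefore expected to stay close to the number of compound 3, which gives 10000 nM in this assay. A step of no change at the digits printed from compound 3 to compound 4 (within the scatter) is expected, no larger than the scatter of the assay and without a clear direction. The estimate for compound 4 in this assay is accordingly 10000 nM, within a range from 4000 nM to 25000 nM.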

Compound 4, half-maximal inhibitory concentration: 8000 nM
Compound 4: middle estimate off by 1.3-fold (0.10 log units), on the high side; low and high end bracket the measured number.
By their numbers in this assay, from the lowest: compound 2; then compounds 4, 1 and 3 (each within the scatter of the next).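

Exchanging the 4-methoxyphenyl of compound 3 for the 4-methylphenyl of compound 4 gives, in this assay, a 1.3-fold lower number from compound 3 to compound 4 (0.10 log units; within the scatter), and this is the only measured step among the compounds shown that differs in one place. It shows that at this position, on an aromatic carbon para to a large group, methyl can stand in for methoxy without the number moving beyond the scatter, even though the oxygen and the one hydrogen-bond acceptor of the methoxy group are gone. No measurement is at hand that would explain this outcome.

From the compounds shown here alone, with only methoxy and methyl at this position, it remains open whether a much different group in the same place, such as an amine, a carboxylic acid or a longer alkyl chain, would shift the number beyond the scatter. Going by these compounds alone, compound 2, the one compound whose number stands clearly apart from that of compound 3, differs from the azide-bearing compounds in more than one place, so the features that set its number apart also remain unresolved.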